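The source may hold more compounds than are shown below. What is called first, only, known or untested is meant among the compounds shown, and "the series" means these compounds.

Measured in a functional assay on HCT-116 cells (Homo sapiens) for antiproliferative activity, read by MTT assay, with a stated time of 48 h; a higher number here means a weaker inhibitor, a lower number a stronger inhibitor:
- Compound 1 `CC(CCO)n1cnc2c(Cl)nc(F)nc21`: 19800 nM
- Compound 2 `CC(CCO)n1cnc2c(Cl)ncnc21`: > 50000 nM (a limit of the assay, not a number)
- Compound 3 `CCCCCCCCCC(CCO)n1cnc2c(Cl)nc(F)nc21`: 32100 nM

For the measured compounds named here, compound 1 holds one of only two numbers in the set, and those two do not separate: a 1.6-fold higher number from compound 1 to compound 3 (0.21 log units; within the scatter). The third value is a limit: the limit of > 50000 nM in this assay, at which 1 of the 3 values shown sits.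

Compound 4 `OCCCn1cnc2c(Cl)nc(F)nc21` is not yet measured. The change is hydrogen in place of methyl on a saturated chain carbon bound to an aromatic nitrogen and a saturated chain carbon.

Going by the values given here, the closest measured change is the one to compound 3, with octyl in place of hydrogen on a saturated chain carbon, two bonds along the chain from an aromatic nitrogen: a 1.6-fold higher number from compound 1 to compound 3 (0.21 log units; within the scatter). A much larger change in that part of the molecule therefore stayed within the scatter, which suggests that removing the methyl will do the same. Hydrogen in place of fluoro on an aromatic carbon gave an at least 2.5-fold higher number from compound 1 to compound 2 (0.40 log units; beyond the scatter), but that change lies at a different place and has little bearing here.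

The estimated step is a 1.2-fold higher number from compound 1 to compound 4 (0.08 log units; within the scatter), so none beyond the scatter is expected. Compound 4 is expected at 24000 nM, with an estimated range of 11000 nM to 50000 nM.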

Compound 4, half-maximal inhibitory concentration: 39800 nM
Estimate against measurement, compound 4: 1.7-fold (0.22 log units) below; low and high end bracket the measured number.
By their numbers in this assay, from the lowest: compounds 1, 3 and 4 (each within the scatter of the next). At a limit, above all of these: compound 2.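

In this assay, hydrogen in place of methyl on the saturated chain carbon bound to an aromatic nitrogen and a saturated chain carbon gives a 2.0-fold higher number from compound 1 to compound 4 (0.30 log units; within the scatter). Until now this part of the molecule had been probed only by adding bulk, with octyl in place of hydrogen giving a 1.6-fold higher number from compound 1 to compound 3 (0.21 log units; within the scatter), so the trimming direction is new. Going from 3-hydroxy-1-methylpropyl to 3-hydroxypropyl therefore does not separate compound 4 from compound 1 in this assay, and the methyl shows no measurable contribution to the number of compound 1, though this step reaches no further than a single pair of compounds.

The chain changes shown all keep the hydroxy, so an amine or a carboxylic acid in its place on the 3-hydroxypropyl chain remains an open question, as does any effect of such a swap on the number of compound 4. Compound 2 carries a limit and not a number, so the full size of the step from fluoro to hydrogen stays unread, and whether it would hold on the 3-hydroxypropyl chain is also open: the limit of > 50000 nM in this assay, at which 1 of the 4 values shown sits.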